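The source may hold more compounds than are shown below. What is called first, only, known or untested is meant among the compounds shown, and "the series" means these compounds.

Measured so far:
compound 1 `Cc1cc(NC(=O)Nc2cc(F)ccc2F)c2ccccc2n1`: 12000 nM
compound 2 `CC(=O)c1ccc(NC(=O)Nc2cc(C)nc3ccccc23)cc1`: > 25000 nM

In an ADME assay on HEK293 cells (Homo sapiens) for cytotoxicity, with a stated time of 72 h (a lower number here means that less compound is needed, a higher number that more compound is needed for the effect), compound 1 gives 12000 nM. For compound 2 only a limit is known: compound 2 gives > 25000 nM, a limit of the assay and not a number, so compound 2 sits at the limit of > 25000 nM in this assay, at which 1 of the 2 values shown sits. Compound 3 `Cc1cc(NC(=O)Nc2ccc(SC(F)(F)F)cc2)c2ccccc2n1` is not yet measured. The change from compound 2 to compound 3 is (trifluoromethyl)sulfanyl in place of acetyl on an aromatic carbon. Within the data shown here, no step between measured compounds is available to size this change, so no large shift beyond the scatter is expected; a small step toward less compound needed is estimated, an at least 1.2-fold lower number from compound 2 to compound 3 (0.09 log units; that floor lies within the scatter). Compound 3 is expected at 20000 nM, in the range 8000 nM to 60000 nM.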

Compound 3, half-maximal effective concentration: 13000 nM
Compound 3: middle estimate off by 1.5-fold (0.19 log units), on the high side; measured number inside the range.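

In this assay, among these compounds, the swap of acetyl for (trifluoromethyl)sulfanyl, on an aromatic carbon para to a large group, gives an at least 1.9-fold lower number from compound 2 to compound 3 (0.28 log units; that floor lies within the scatter) as the first sized step. Compound 3 gives 13000 nM as a measured number, so this group brings the read-out inside the range of the assay. The step stands only as a floor because compound 2 is held at a limit, which is not a number: the limit of > 25000 nM in this assay, at which 1 of the 3 values shown sits.

As far as these compounds go, the true size of the step, and whether it goes beyond the scatter, stays open. Also open, from the compounds shown here alone, is how an amine or a carboxylic acid at this position would shift the number.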